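Swapping 2-fluorophenyl for (4-methylphenyl)carbonyl on an amine nitrogen

The source may report more compounds than this note shows. Statements on the series, on what has been measured and on what is new or still open speak of the compounds shown alone.

In a functional assay on A549 cells (Homo sapiens) for antiproliferative activity, read by MTT assay, with a stated time of 24 h (a higher number here means a weaker inhibitor, a lower number a stronger inhibitor), compound 1 `Cc1cccc(NNC(=O)c2ccc(NS(=O)(=O)c3cnc(O)nc3O)cc2)c1` gives > 20000 nM, which is a limit of the assay and not a number. For the measured compounds named here, compound 2 `O=C(NNc1ccccc1F)c1ccc(NS(=O)(=O)c2cnc(O)nc2O)cc1` gives 11700 nM, the only actual number so far. Compound 3 `Cc1ccc(C(=O)NNC(=O)c2ccc(NS(=O)(=O)c3cnc(O)nc3O)cc2)cc1` differs from compound 2 by (4-methylphenyl)carbonyl in place of 2-fluorophenyl on an amine nitrogen. Going by the values given here, the sole measured step, an at least 1.7-fold lower number from compound 1 to compound 2 (0.23 log units; that floor lies within the scatter), exchanges another group at this amine nitrogen and is bounded by the limit of > 20000 nM in this assay, at which 1 of the 2 values shown sits. It gives little guidance, so compound 2 at 11700 nM serves as the anchor. The expected change is small: a 1.3-fold higher number from compound 2 to compound 3 (0.11 log units; within the scatter). For compound 3 the estimate is 15000 nM, with an expected range of 6000 nM to 35000 nM.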

Compound 3, half-maximal inhibitory concentration: 15900 nM
The estimate for compound 3 lay 1.1-fold (0.03 log units) below the measured number, within the range that was stated.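

On this amine nitrogen, (4-methylphenyl)carbonyl in place of 2-fluorophenyl adds a carbonyl and a hydrogen-bond acceptor, yet this assay gives a 1.4-fold higher number from compound 2 to compound 3 (0.13 log units; within the scatter), so the two groups are not separated here. Compound 1 carries a limit and not a number, so an at least 1.2-fold lower number from compound 1 to compound 3 (0.09 log units; that floor lies within the scatter) fixes no size: the limit of > 20000 nM in this assay, at which 1 of the 3 values shown sits.

As far as these compounds go, whether any group on this nitrogen can move the number beyond the scatter remains open. A short alkyl chain such as ethyl, or a phenyl ring bearing a carboxylic acid, would probe this.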